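Glutamine side chain at the glycine position of compound 2

A few compounds are considered here, and "the series" means these few. Any claim that something is new, unique, unknown or untested is made for them only; others in the source may bear on it.

Measured so far:
compound 1 `CSCC[C@H](NC(=O)[C@H](CC(C)C)NC(=O)[C@H](CO)NC(=O)CC[C@H](NS(=O)(=O)c1ccc(Cl)c(C(F)(F)F)c1)C(=O)O)C(N)=O` — 5700 nM
compound 2 `CSCC[C@H](NC(=O)[C@H](CC(C)C)NC(=O)CNC(=O)CC[C@H](NS(=O)(=O)c1ccc(Cl)c(C(F)(F)F)c1)C(=O)O)C(N)=O` — 120 nM

In an assay on isolated protein for inhibition of Matrilysin (Homo sapiens), read by fluorescence, with a stated time of 15 min (on this read-out higher numbers stand for weaker inhibition and lower numbers for stronger inhibition), compound 2 gives 120 nM, the lowest of the two numbers recorded; its nearest neighbour is compound 1, which gives 5700 nM. Going by the values given here, the one step measured so far, a 48-fold lower number from compound 1 to compound 2 (1.68 log units; beyond the scatter), came from replacing hydroxymethyl with hydrogen on a saturated chain carbon bound to an amide-type nitrogen and a carbonyl carbon.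

Compound 3 `CSCC[C@H](NC(=O)[C@H](CC(C)C)NC(=O)[C@H](CCC(N)=O)NC(=O)CC[C@H](NS(=O)(=O)c1ccc(Cl)c(C(F)(F)F)c1)C(=O)O)C(N)=O` is not yet measured. It differs from compound 2 by 2-carbamoylethyl in place of hydrogen on a saturated chain carbon bound to an amide-type nitrogen and a carbonyl carbon, so the same position is substituted again, now with a larger group carrying one hydrogen-bond donor and one acceptor. Among the compounds with values here, the only step that bears on it is the one from compound 1 to compound 2, where a substituent at this position went with a much higher number. Because a 48-fold lower number from compound 1 to compound 2 (1.68 log units; beyond the scatter) was large, a higher number is expected for compound 3 in this assay, though the new group is not the one removed, so the size is uncertain. The step from compound 2 to compound 3 is estimated at a 13-fold higher number from compound 2 to compound 3 (1.10 log units; beyond the scatter). The estimate for compound 3 is 1500 nM, with a range from 300 nM to 8000 nM.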

Compound 3, half-maximal inhibitory concentration: 1300 nM
Beside the measured number, compound 3's estimate is 1.2-fold (0.06 log units) above it, within the range that was stated.
By their numbers in this assay, from the lowest: compound 2; then compound 3; then compound 1.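

In this assay, hydrogen on the saturated chain carbon bound to an amide-type nitrogen and a carbonyl carbon now compares with two different substituents, and 2-carbamoylethyl also goes with a higher number: an 11-fold higher number from compound 2 to compound 3 (1.03 log units; beyond the scatter). Going by these compounds alone, the earlier 48-fold lower number from compound 1 to compound 2 (1.68 log units; beyond the scatter) therefore no longer stands as a result for hydroxymethyl alone, and among the three compounds hydrogen gives the lowest number, with no compound going against this. The substituents are not interchangeable either, since a 4.4-fold lower number from compound 1 to compound 3 (0.64 log units; beyond the scatter) shows that the penalty at this position depends on the group, though no available data account for this difference or for the preference for hydrogen.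

The compounds shown leave open whether a plain methyl group at this position already goes with a higher number than hydrogen, which would test whether any substituent there carries a penalty. Also open, as far as these compounds go, is how a carboxylic acid or a primary amine at the end of a chain on this carbon would compare with the 2-carbamoylethyl group of compound 3.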